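The source may hold more compounds than are shown below. What is called first, only, known or untested is meant among the compounds shown, and "the series" means these compounds.

Compound 1, `Cc1ccc(C(=O)Nc2cccc(-c3oc4cc(-c5ccc(F)cc5)ccc4c(=O)c3O)c2)cc1`: in a functional assay on HepG2 cells (Homo sapiens) for antiproliferative activity, read by CCK-8 assay, with a stated time of 72 h (a higher number here means a weaker inhibitor, a lower number a stronger inhibitor), compound 1 gives 2320 nM.
Compound 2, `O=C(Nc1cccc(-c2oc3cc(-c4ccc(F)cc4)ccc3c(=O)c2O)c1)c1ccc(C(F)(F)F)cc1`: in this assay compound 2 gives 42700 nM.

Among the compounds with values here, of the two numbers in this assay, compound 2 stands at the higher one, and the single measured step, an 18-fold higher number from compound 1 to compound 2 (1.26 log units; beyond the scatter), separates it from compound 1. Compound 3, `O=C(Nc1cccc(-c2oc3cc(-c4ccc(F)cc4)ccc3c(=O)c2O)c1)c1ccc(Br)cc1`, differs from compound 2 by bromo in place of trifluoromethyl on an aromatic carbon. Within the data shown here, the only step that bears on this change is an 18-fold higher number from compound 1 to compound 2 (1.26 log units; beyond the scatter), which sits at the same position but exchanges methyl for trifluoromethyl, not trifluoromethyl for bromo; no step with bromo at that position has been measured. With the trifluoromethyl of compound 2 leaving, a number between those of compound 2 and compound 1 is expected, so compound 3 is estimated to give a lower number than compound 2 in this assay, a step of a 5.3-fold lower number from compound 2 to compound 3 (0.73 log units; beyond the scatter). Compound 3 is therefore expected at 8000 nM, within a range from 1500 nM to 45000 nM.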

Compound 3, half-maximal inhibitory concentration: 13900 nM
Compound 3: the middle estimate sits 1.7-fold (0.24 log units) below what was measured; low and high end bracket the measured number.
By their numbers in this assay, from the lowest: compound 1; then compound 3; then compound 2.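

With bromo in place of trifluoromethyl on the aromatic carbon, this assay shows a 3.1-fold lower number from compound 2 to compound 3 (0.49 log units; beyond the scatter) and so gives back part of the rise in number seen with trifluoromethyl. Bromo does not return to the level of methyl, since the same assay shows a 6.0-fold higher number from compound 1 to compound 3 (0.78 log units; beyond the scatter) and thus places compound 3 clearly apart from both neighbours. This one position therefore now carries a graded series of three groups, with methyl at the lowest number, bromo in the middle and trifluoromethyl at the highest, and nothing measured here explains that order.

As far as these compounds go, whether a chloro, a methoxy, a nitrile or an amine at this position would fit into the same series remains open. So does whether any group there, or a bare hydrogen, would give a number lower than that of compound 1.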